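The source may report more compounds than this note shows. Statements on the series, on what has been measured and on what is new or still open speak of the compounds shown alone.

Of the compounds shown here, three sharing one core have been tested in a functional assay on BCG823 cells (Homo sapiens) for inhibition, read by MTT assay, with a stated time of 72 h; on this read-out higher numbers stand for weaker inhibition and lower numbers for stronger inhibition. Compound 1 `CN(C(=O)NC(=O)c1ccc(F)c(F)c1)c1nc(C(F)(F)F)c(C(=O)N/N=C/c2ccc(C(F)(F)F)cc2)s1` gives 3.85 ug/mL, compound 2 `CN(C(=O)NC(=O)c1ccc(F)c(F)c1)c1nc(C(F)(F)F)c(C(=O)N/N=C/c2ccccc2C(F)(F)F)s1` gives 3.66 ug/mL, and compound 3 `CN(C(=O)NC(=O)c1ccc(F)c(F)c1)c1nc(C(F)(F)F)c(C(=O)N/N=C/c2ccc([N+](=O)[O-])cc2)s1` gives 2.99 ug/mL. Compound 2 holds the second highest of these three numbers, its nearest neighbour being compound 1 and its furthest compound 3. The measured steps are small: a 1.1-fold lower number from compound 1 to compound 2 (0.02 log units; within the scatter), a 1.3-fold lower number from compound 1 to compound 3 (0.11 log units; within the scatter) and a 1.2-fold lower number from compound 2 to compound 3 (0.09 log units; within the scatter). All three touch only the aryl group on the carbon with a double bond to nitrogen.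

Compound 4 `CN(C(=O)NC(=O)c1c(Cl)cccc1Cl)c1nc(C(F)(F)F)c(C(=O)N/N=C/c2ccccc2C(F)(F)F)s1` is not yet measured. It differs from compound 2 at the other end of the molecule: 2,6-dichlorophenyl in place of 3,4-difluorophenyl on a carbonyl carbon. Going by the values given here, no measured step changes this part, so there is no direct precedent; the only guidance is that every step so far stayed within the scatter. Compound 4 is therefore expected to show a 1.0-fold higher number from compound 2 to compound 4 (0.00 log units; within the scatter) in this assay, with no direction beyond the scatter. The estimate for compound 4 is 3.7 ug/mL, expected to lie between 1.8 ug/mL and 7.5 ug/mL.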

Compound 4, half-maximal inhibitory concentration: 4.12 ug/mL
The estimate for compound 4 lay 1.1-fold (0.05 log units) below the measured number, and the stated range covers the measured number.
By their numbers in this assay, from the lowest: compounds 3, 2, 1 and 4 (each within the scatter of the next).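

Going by these compounds alone, this is the first step at the other end of the molecule, on a carbonyl carbon whose other neighbour is an amide-type nitrogen, and in this assay 2,6-dichlorophenyl in place of 3,4-difluorophenyl gives a 1.1-fold higher number from compound 2 to compound 4 (0.05 log units; within the scatter). The earlier compounds shown here varied only the aryl group on the carbon with a double bond to nitrogen, so this part of the molecule now has its first reading: exchanging one halogenated phenyl group for another here leaves the number within the scatter. Nothing at hand speaks to the reason for this result.

The compounds shown leave open how this position responds to a group other than a halogenated phenyl, such as a longer alkyl chain, an amine or a carboxylic acid. They also leave open whether 2,6-dichlorophenyl gives the same reading when paired with 4-nitrophenyl at the other end of the molecule.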